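Bromo on compound 2: expected step in antiproliferative potency

The source may hold more compounds than are shown below. What is called first, only, known or untested is meant among the compounds shown, and "the series" means these compounds.

For the measured compounds named here, in a functional assay on Hs 683 cells (Homo sapiens) for antiproliferative activity, read by MTT assay, with a stated time of 72 h (a lower number here means a stronger inhibitor, a higher number a weaker inhibitor), compound 1 (`O=C1Nc2c(F)cccc2/C1=C1/Nc2ccccc2C1=O`) gives 38700 nM as the only actual number so far. Compound 2 (`O=C1Nc2ccccc2/C1=C1/Cc2ccccc2C1=O`) gives > 100000 nM as a limit of the assay and not a number. Compound 3 (`O=C1Nc2ccc(Br)cc2/C1=C1/Cc2ccccc2C1=O`) is still unmeasured and differs from compound 2 by one change: bromo in place of hydrogen on an aromatic carbon with bromo in place of hydrogen on an aromatic carbon. Going by the values given here, no measured step in this assay gives the size of such a change, so the expectation is loose. A modest gain in potency is expected, towards a lower number, and the reading may still come back as a limit. The estimate means a step of an at least 2.2-fold lower number from compound 2 to compound 3 (0.34 log units; beyond the scatter) as the expected shift. Compound 3 is estimated at 45000 nM with an expected range from 15000 nM to 100000 nM as the upper end.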

Compound 3, half-maximal inhibitory concentration: 47300 nM
The estimate for compound 3 lay 1.1-fold (0.02 log units) below the measured number; the measured number falls inside the stated range.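

In this assay, bromo in place of hydrogen on an aromatic carbon, meta to a fused ring and para to a fused ring, produces an at least 2.1-fold lower number from compound 2 to compound 3 (0.32 log units; beyond the scatter). This single change is enough to turn a reading with no number into a measurable value, so this position on the core of compound 2 can affect antiproliferative potency. The value for compound 2 is a limit and not a number, and the step can therefore be given only as a minimum, because its true size depends on where compound 2 actually lies: the limit of > 100000 nM in this assay, at which 1 of the 3 values shown sits.

From the compounds shown here alone, whether this gain is specific to bromo remains open, since an amine, a carboxylic acid or a methoxy group at the same carbon could give a different step. Going by these compounds, whether bromo acts similarly on other carbons of this ring also remains open.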